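From a hexyl ether to a cyclohexylmethyl ether

A few compounds are considered here, and "the series" means these few. Any claim that something is new, unique, unknown or untested is made for them only; others in the source may bear on it.

Of the compounds shown here, two have been tested in a functional assay on NUGC-3 cells (Homo sapiens) for antiproliferative activity, read by sulforhodamine B assay (on this read-out higher numbers stand for weaker inhibition of growth and lower numbers for stronger inhibition of growth), and neither gives a number. Compound 1 (`COc1cccc(OCCC(C)(C)C)c1C(=O)/C=C/c1ccc(O)cc1`) reads > 30000 nM as a limit of the assay. Compound 2 (`CCCCCCOc1cccc(O)c1C(=O)/C=C/c1ccc(O)cc1`) reads > 30000 nM as a limit too. Among the measured compounds shown here, the series so far stands at the limit of > 30000 nM in this assay, at which 2 of the 2 values shown sit, and compound 2 sits there with no number from which a step could be counted.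

Compound 3 (`O=C(/C=C/c1ccc(O)cc1)c1c(O)cccc1OCC1CCCCC1`) keeps the core of compound 2 and carries cyclohexyl in place of pentyl on a saturated chain carbon bound to an oxygen on an aromatic ring. Cut one bond further out, the same difference reads hexyloxy to cyclohexylmethoxy. For the measured compounds named here, no measured step gives a scale for this change, so the expectation is a cautious one. The expected change is an at least 1.5-fold lower number from compound 2 to compound 3 (0.17 log units; that floor lies within the scatter) and it is taken as a modest move toward stronger inhibition of growth, with another reading at the limit quite possible. Compound 3 is estimated at 20000 nM with an expected range from 5000 nM to 30000 nM in this assay.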

Compound 3, concentration for 50% growth inhibition: > 30000 nM
Compound 3 ended at the assay's limit; the forecaster's own chance of this, stated with the estimate: 50%; middle value at least 1.5-fold (0.17 log units) away from the limit.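

In this assay compound 3 gives > 30000 nM, which is a limit of the assay and not a number. Among the compounds shown here, compound 2 also stands at a limit, so no step from compound 2 to compound 3 can be read. The compounds shown leave open whether any ether in this series gives a measurable inhibition of growth: the limit of > 30000 nM in this assay, at which 3 of the 3 values shown sit.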